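The compounds below may be only part of what the source reports. "The series", "measured", "known", "first", "only" and "open" are said of these compounds alone.

Measured so far:
- compound 1, `OC(CSc1[nH]cnc2ncnc1-2)CN1CCN(C(c2ccc(Br)cc2)c2ccc(Br)cc2)CC1`: in a functional assay on muscle tissue (Mustela putorius furo) (a higher number here means a larger maximal response, a lower number a smaller maximal response), compound 1 reaches 64%
- compound 2, `CC(=O)OC(CSc1[nH]cnc2ncnc1-2)CN1CCN(C(c2ccc(F)cc2)c2ccc(F)cc2)CC1`: in this assay compound 2 reaches 248%

Compound 2 stands highest of the two numbers; the nearest, compound 1, lies well below it, and the gap between them is beyond the usual scatter. Within the data shown here, no single-point step connects the two, as compound 1 and compound 2 differ in more than one place, so their values are only read side by side.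

Compound 3, `O=S(=O)(O)OC(CSc1[nH]cnc2ncnc1-2)CN1CCN(C(c2ccc(F)cc2)c2ccc(F)cc2)CC1`, remains to be measured. It differs from compound 2 by sulfo in place of acetyl on an oxygen on a saturated carbon. Among the measured compounds shown here, no measured step of the same kind is available, so the expectation rests on the standing of compound 2 alone. A downward step from compound 2 to compound 3, somewhat beyond the scatter, is expected, as a number 78 percentage points lower from compound 2 to compound 3 (beyond the scatter). For compound 3 the estimate is 170%, with a range from 70% to 260%.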

Compound 3, largest response reached (reported as maximum), in percent of the reference or control that the assay uses: 57%
Estimate against measurement, compound 3: 113 percentage points above; measured number outside the range, below it.
By their numbers in this assay, from the lowest: compounds 3 and 1 (each within the scatter of the next); then compound 2.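

Among these compounds, the oxygen on a saturated carbon now gives the first single-place step. In this assay the change from acetyl to sulfo at this oxygen gives a number 191 percentage points lower from compound 2 to compound 3 (beyond the scatter) and shows that the maximal response depends strongly on the group carried there, with the rest of compound 2 unchanged. Nothing shown accounts for the size of this step.

Only acetyl and sulfo can be compared directly at this oxygen, so a single step does not show how the response changes across other groups. A free hydroxyl, a propanoyl group or a phosphono group on the same oxygen would help place this drop, and the hydroxyl of compound 1 cannot fill that gap since that compound carries bromine rather than fluorine on its aromatic rings.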